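This account rests on a few compounds, and the source may have more. Where it says the series, first, only, none or still open, it means among the compounds named here.

Working notes on the series. In a functional assay on PC-3 cells (Homo sapiens) for antiproliferative activity, read by MTT assay, with a stated time of 72 h (on this read-out lower numbers stand for stronger inhibition and higher numbers for weaker inhibition), compound 1 `CCN(CC)CCNC(=O)c1ccc(C(CC)(CC)c2ccc(OCC(O)C(C)(C)C)c(C)c2)n1CC` gives 2800 nM and compound 2 `CCn1cc(C(CC)(CC)c2ccc(C#CC(O)(CC)CC)c(C)c2)cc1C(=O)NCC(=O)OC` gives 17500 nM as the higher of the two numbers, a gap beyond the scatter. Compound 3 `CCn1cc(C(CC)(CC)c2ccc(C#CC(O)(CC)CC)c(C)c2)cc1C(=O)N[C@H](C(=O)O)C(C)C` departs from compound 2 at one place only: 1-carboxy-2-methylpropyl in place of (methoxycarbonyl)methyl on an amide-type nitrogen on the amide side chain, with 1-carboxy-2-methylpropyl in place of (methoxycarbonyl)methyl on an amide-type nitrogen. Among the measured compounds shown here, no step between measured compounds shows what a change at this place does, and compound 1 differs from compound 2 in more than one place. The expectation is therefore loose. In this assay a small move toward weaker inhibition is expected, and it may not exceed the scatter. The expected size is a 1.5-fold higher number from compound 2 to compound 3 (0.17 log units; within the scatter) on this estimate, with a wide margin on either side. For compound 3 the estimate is 26000 nM with an expected range from 9000 nM to 75000 nM in this read-out.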

Compound 3, half-maximal inhibitory concentration: 3750 nM
For compound 3 the middle estimate is 6.9-fold (0.84 log units) above the measured one; the whole stated range lies above it.
By their numbers in this assay, from the lowest: compounds 1 and 3 (each within the scatter of the next); then compound 2.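

In this assay, among the compounds shown here, 1-carboxy-2-methylpropyl in place of (methoxycarbonyl)methyl on an amide-type nitrogen gives a 4.7-fold lower number from compound 2 to compound 3 (0.67 log units; beyond the scatter), the first reading at this place, so the group on this nitrogen can move the number beyond the scatter, here toward stronger inhibition. The change is compound in nature: the methyl ester gives way to a carboxy group, the chain grows and branches, and a defined stereocentre enters, so this single step cannot assign the gain to any one of these. Nothing measured here gives a reason for the step.

Still open, as far as these compounds go, is which of these features carries the step: a carboxymethyl group on the same nitrogen would test the carboxy group without the branch, and the methyl ester of the 1-carboxy-2-methylpropyl group would test the branch without the free acid. From the compounds shown here alone, the effect of the opposite stereocentre at this carbon also remains open.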